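A few compounds are considered here, and "the series" means these few. Any claim that something is new, unique, unknown or untested is made for them only; others in the source may bear on it.

Measured so far:
compound 1 `CC(C)=CCC[C@]1(C)/C=C/[C@@H](OC(=O)C=C(C)C)[C@](C)(O)/C=C/C(=O)/C(CCl)=C\C1` — 840 nM
compound 2 `CC(C)=CCC[C@]1(C)/C=C/[C@@H](OC(=O)C=C(C)C)[C@](C)(O)CCC(=O)/C(CO)=C\C1` — > 40000 nM

Going by the values given here, in a functional assay on SMMC-7721 cells (Homo sapiens) for antiproliferative activity, read by MTT assay, with a stated time of 48 h (on this read-out higher numbers stand for weaker inhibition and lower numbers for stronger inhibition), compound 1 gives 840 nM, and this is the only number. Compound 2 reaches only the limit > 40000 nM in this assay, which is the limit of > 40000 nM in this assay, at which 1 of the 2 values shown sits. Among the compounds with values here, compound 1 and compound 2 differ in more than one place, so the two values show only that compound 1 has a measured number and compound 2 does not.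

Compound 3 `CSC(=S)OC/C1=C/C[C@](C)(CCC=C(C)C)/C=C/[C@@H](OC(=O)C=C(C)C)[C@](C)(O)/C=C/C1=O` differs from compound 1 by a group of 5 heavy atoms (2 carbon, 1 oxygen, 2 sulfur; no ring) in place of one chlorine atom, on a saturated chain carbon bound to a double-bonded ring carbon. Within the data shown here, no comparable step has been measured in this assay, so the expectation rests on the structures alone: a modest step, beyond the scatter but not large, toward weaker inhibition. Compound 3 is therefore expected to give 1800 nM in this assay, with a range of 500 nM to 7000 nM, the expected step being a 2.1-fold higher number from compound 1 to compound 3 (0.33 log units; beyond the scatter).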

Compound 3, half-maximal inhibitory concentration: 720 nM
Compound 3: middle estimate off by 2.5-fold (0.40 log units), on the high side; low and high end bracket the measured number.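

In this assay the step is a 1.2-fold lower number from compound 1 to compound 3 (0.07 log units; within the scatter) for a group of 5 heavy atoms (2 carbon, 1 oxygen, 2 sulfur; no ring) in place of one chlorine atom, on a saturated chain carbon bound to a double-bonded ring carbon. This first single-place comparison in the series shows that, on the core of compound 1, the chloro group can give way to this larger group with 3 hydrogen-bond acceptors and no change beyond the scatter. Nothing shown accounts for this result.

Going by these compounds, whether an amine or a carboxylic acid on this carbon would also hold the value remains open. Compound 2 gives > 40000 nM in this assay as a limit of the assay, and it differs from compound 1 in more than one place, so it does not settle the role of this position alone.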